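The compounds below may be only part of what the source reports. "The series", "measured", "known", "first", "only" and "open" are said of these compounds alone.

Measured compounds and their values in a physicochemical assay for solubility, read by spectrophotometry, in phosphate buffer, with a stated time of 2 h, at pH 7.4; on this read-out lower numbers stand for lower solubility and higher numbers for higher solubility:

Compound 1 `COc1ccc2[nH]c(C(=O)N3CC(=O)N(Cc4ccccc4)[C@@H](COCc4ccccc4)C3)cc2c1` gives 8800 nM in this assay.
Compound 2 `COc1cccc(CN2C(=O)CN(C(=O)c3cc4cc(OC)ccc4[nH]3)C[C@@H]2CCc2ccccc2)c1` gives 5100 nM in this assay.
Compound 3 `COc1cccc(CN2C(=O)CN(C(=O)c3cc4cc(OC)ccc4[nH]3)C[C@@H]2c2ccccc2)c1` gives 13600 nM in this assay.

Among these three, compound 3 gives the highest number. Compound 1 stands nearest to it, at a gap within the scatter, so the two cannot be ordered on these data. Compound 2 stands furthest, at a gap beyond the scatter. Going by the values given here, the one single-point step among the measured compounds is a 2.7-fold higher number from compound 2 to compound 3 (0.43 log units; beyond the scatter), at the saturated ring carbon that carries the varied group.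

Compound 4 `COc1cccc(CN2C(=O)CN(C(=O)c3cc4cc(OC)ccc4[nH]3)C[C@@H]2Cc2ccccn2)c1` differs from compound 3 by (pyridin-2-yl)methyl in place of phenyl on a saturated ring carbon. Among the compounds with values here, no measured pair covers this particular exchange. Within the data shown here, the only measured step at the same position, a 2.7-fold higher number from compound 2 to compound 3 (0.43 log units; beyond the scatter), was modest and ran toward higher numbers; it took a larger group out for a smaller one, whereas here a group of similar size to the one that leaves comes in, carrying one ring nitrogen. Among the measured compounds shown here, there is thus no measured step that points clearly in either direction, and nothing suggests a move larger than the measured step.

Compound 4 is therefore expected to give 14000 nM in this assay, with a range from 6000 nM to 32000 nM. The expected step of a 1.0-fold higher number from compound 3 to compound 4 (0.01 log units; within the scatter) is estimated to lie within the scatter.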

Compound 4, solubility: 57900 nM
Compound 4: the middle estimate sits 4.1-fold (0.62 log units) below what was measured; the whole stated range lies below it.
By their numbers in this assay, from the lowest: compounds 2, 1 and 3 (each within the scatter of the next, the first and the last beyond it); then compound 4.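

In this assay, the saturated ring carbon next to the ring nitrogen can shift the number further than the earlier step showed: (pyridin-2-yl)methyl in place of phenyl gives a 4.3-fold higher number from compound 3 to compound 4 (0.63 log units; beyond the scatter). This goes against reading the earlier step as smaller group, higher number, as the larger group here carries the higher number, and pyridin-2-yl in place of benzyl on the saturated chain carbon bound to that ring carbon gives an 11-fold higher number from compound 2 to compound 4 (1.06 log units; beyond the scatter), the largest step among the compounds shown. No measurement is available that explains either step.

The exchange from phenyl changes both the chain and the ring at once. The data shown do not tell the ring nitrogen and the chain apart in this step; a benzyl group on the same ring carbon would separate the two. On these data alone, whether the placement of the ring nitrogen matters also stays open, and (pyridin-3-yl)methyl or (pyridin-4-yl)methyl at this carbon would address that.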